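The source may report more compounds than this note shows. Statements on the series, on what has been measured and on what is new or still open speak of the compounds shown alone.

Measured compounds:
compound 1 `C/C(C(=O)NC1CC1)=C(/C)c1cccc(C(F)(F)F)c1` — 17.4 mg/kg
compound 2 `C/C(=C\c1cccc(C(F)(F)F)c1)C(N)=O` — 22.4 mg/kg
compound 3 `C/C(C(N)=O)=C(\C)c1cccc(C(F)(F)F)c1` — 32.2 mg/kg

In a functional assay on the whole organism with Mus musculus as the target (on this read-out lower numbers stand for an effect already at smaller amounts and higher numbers for an effect only at larger amounts of compound), compound 3 has the highest of the three numbers, yet its gaps to compound 2 and to compound 1 both fall inside the usual scatter, so none of the three can be called stronger or weaker than another. Compound 4 `C/C(C(=O)NC1CC1)=C(\C)c1cccc(C(F)(F)F)c1` arises from compound 3 by a single change: cyclopropyl in place of hydrogen on an amide-type nitrogen. Among the measured compounds shown here, no pair of measured compounds differs only by this change, so no measured step is known for it. Still, compound 1, which also carries the cyclopropylcarbamoyl group, gives 17.4 mg/kg in this assay, which suggests at most a small step, if any. Compound 4 is therefore expected at about 20 mg/kg, within 10 mg/kg to 40 mg/kg, an estimated step of a 1.6-fold lower number from compound 3 to compound 4 (0.21 log units; within the scatter).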

Compound 4, dose for half-maximal effect: 65.5 mg/kg
Estimate against measurement, compound 4: 3.3-fold (0.52 log units) below; measured number above the stated range.
By their numbers in this assay, from the lowest: compounds 1, 2 and 3 (each within the scatter of the next); then compound 4.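

In this assay, cyclopropyl in place of hydrogen on the amide-type nitrogen gives a real loss, with a 2.0-fold higher number from compound 3 to compound 4 (0.31 log units; beyond the scatter). The same group with the other double-bond configuration gives a larger gap, with a 3.8-fold higher number from compound 1 to compound 4 (0.58 log units; beyond the scatter). That gap can only come from the double bond: the fact that compounds 1 and 4 differ only in the configuration as drawn

Still open, from the compounds shown here alone, is whether the carbamoyl compound with the double bond drawn as in compound 1 would show a similar gap to its own isomer, compound 3. Also open, going by these compounds, is how a methyl group or a longer chain on that nitrogen would behave under either configuration.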